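Chloro in Place of (Ethylsulfanyl)methyl on the Shared Core

This account rests on a few compounds, and the source may have more. Where it says the series, first, only, none or still open, it means among the compounds named here.

Compound 2 `CCSCc1c(C)nc2c(OCc3ccccc3)cccn12` stands lowest of the two numbers shown in a functional assay on the whole organism (stomach) for inhibition, with Canis familiaris (Canis lupus familiaris) as the target, at a dose of 5 mg/kg by the intravenous route (a lower number here means a weaker effect, a higher number a stronger effect of the compound at the dose given), giving 0%; its nearest neighbour is compound 1 `Cc1nc2c(OCc3ccccc3)cccn2c1C#N`, which in this assay gives 4%, and the step between them is a number 4 percentage points lower from compound 1 to compound 2 (within the scatter). Compound 3 `Cc1nc2c(OCc3ccccc3)cccn2c1Cl` differs from compound 2 as follows: chloro in place of (ethylsulfanyl)methyl on an aromatic carbon. Within the data shown here, the only measured step that bears on this change, a number 4 percentage points lower from compound 1 to compound 2 (within the scatter), lay within the scatter, so the expected step is a number 3 percentage points higher from compound 2 to compound 3 (within the scatter). Compound 3 is therefore estimated at 3%, with a range from 0% to 15%.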

Compound 3, a percentage reported as inhibition, in the whole organism at one dose (the size of the read-out at that dose, not a potency): 37%
The estimate for compound 3 lay 34 percentage points below the measured number, outside the stated range (above it).
By their numbers in this assay, from the lowest: compounds 2 and 1 (each within the scatter of the next); then compound 3.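

In this assay chloro on this aromatic carbon gives a number 37 percentage points higher from compound 2 to compound 3 (beyond the scatter) in place of (ethylsulfanyl)methyl, and a number 33 percentage points higher from compound 1 to compound 3 (beyond the scatter) in place of the nitrile. The position therefore responds to the group it carries, which the small step between the two earlier compounds had not shown. Nothing available explains why chloro behaves differently here.

On these data alone, whether this gain belongs to chloro alone stays open, since bromo, fluoro or an amine on the same carbon could give either a similar or a much lower number.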